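Trifluoromethylpyrazole amide on the shared core

The source may hold more compounds than are shown below. What is called first, only, known or untested is meant among the compounds shown, and "the series" means these compounds.

Compound 1 `CC1(C)Cc2c(sc(NC(=O)c3cn[nH]c3)c2C(N)=O)C(C)(C)O1` is measured in an assay on cells for positive allosteric modulation of Cystic fibrosis transmembrane conductance regulator variant F508del (Homo sapiens), with stated times of 10 min and 7 s, in the presence of a further agent that is not named here (a lower number here means that less compound is needed, a higher number that more compound is needed for the effect), where compound 1 gives 125 nM. Among the three measured compounds, compound 1 stands second highest in number. Its nearest neighbour is compound 2 `CC1(C)Cc2c(sc(NC(=O)Cc3ccn[nH]3)c2C(N)=O)C(C)(C)O1`, which in this assay gives 136 nM; the step of a 1.1-fold higher number from compound 1 to compound 2 (0.04 log units; within the scatter) lies within the scatter. Furthest away is compound 3 `CC1(C)Cc2c(sc(NC(=O)C3(CO)CC3)c2C(N)=O)C(C)(C)O1`, which in this assay gives 15 nM, so that an 8.3-fold lower number from compound 1 to compound 3 (0.92 log units; beyond the scatter) and likewise a 9.1-fold lower number from compound 2 to compound 3 (0.96 log units; beyond the scatter) are beyond the scatter.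

Compound 4 `CC1(C)Cc2c(sc(NC(=O)c3cc(C(F)(F)F)n[nH]3)c2C(N)=O)C(C)(C)O1` is not yet measured. It differs from compound 1 in one place: 3-(trifluoromethyl)-1H-pyrazol-5-yl in place of 1H-pyrazol-4-yl on a carbonyl carbon. The change keeps the pyrazole amide and adds a trifluoromethyl group to it.

Of the measured steps, only a 1.1-fold higher number from compound 1 to compound 2 (0.04 log units; within the scatter) stays with a pyrazole and it is within the scatter, while an 8.3-fold lower number from compound 1 to compound 3 (0.92 log units; beyond the scatter) replaces the pyrazole altogether and is not a close guide. Going by the values given here, no measured step tests a trifluoromethyl on the pyrazole, so the expectation is a step of a 1.1-fold lower number from compound 1 to compound 4 (0.06 log units; within the scatter) that is not clearly beyond the scatter in either direction. Compound 4 is therefore expected to give about 110 nM in this assay, with a range from 35 nM to 350 nM.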

Compound 4, half-maximal effective concentration: 3 nM
For compound 4 the middle estimate is 37-fold (1.56 log units) above the measured one, outside the stated range (below it).
By their numbers in this assay, from the lowest: compound 4; then compound 3; then compounds 1 and 2 (each within the scatter of the next).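

On the carbonyl carbon whose other neighbour is the amide-type nitrogen, 3-(trifluoromethyl)-1H-pyrazol-5-yl in place of 1H-pyrazol-4-yl gives in this assay a 42-fold lower number from compound 1 to compound 4 (1.62 log units; beyond the scatter) and thus shows that this position can respond strongly even when a pyrazole amide is kept. The earlier pyrazole compounds had both stood well behind the 1-(hydroxymethyl)cyclopropyl group, yet the result now gives a 5.0-fold lower number from compound 3 to compound 4 (0.70 log units; beyond the scatter) and so puts a pyrazole ahead of that group. Against the pyrazole with the extra carbon before the ring, the change gives a 45-fold lower number from compound 2 to compound 4 (1.66 log units; beyond the scatter) and leaves compound 4 with the lowest number of the four, with each of its steps beyond the scatter.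

The compounds shown leave open whether this large step belongs to the trifluoromethyl group or to the move from 1H-pyrazol-4-yl to a 1H-pyrazol-5-yl attachment, and whether a methyl group or a chlorine atom in place of trifluoromethyl would have the same effect. No accompanying measurement bears on what lies behind the step.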